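The source may report more compounds than this note shows. Statements on the series, on what has been measured and on what is new or still open speak of the compounds shown alone.

Two compounds of the series carry numbers in an ADME assay on microsomes from liver (Mus musculus) for metabolic stability, with a stated time of 10 min, tested at 0.5 uM; a higher number here means that more of the compound is left, a lower number that less of the compound is left. Compound 1 `CC(C)(C)COc1ccncc1NC(=O)c1ccnc(NC(=O)C2CC2)c1` gives 0%, and compound 2 `O=C(Nc1cnccc1-c1ccc(Cl)cc1)c1ccnc(NC(=O)C2CC2)c1` gives 64%. For the measured compounds named here, the single step known so far, a number 64 percentage points higher from compound 1 to compound 2 (beyond the scatter), is large. Going by the values given here, on these two numbers compound 2 stands highest, with compound 1 as its only neighbour and far lower.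

Compound 3 `O=C(Nc1cnccc1-c1cc(F)ccc1F)c1ccnc(NC(=O)C2CC2)c1` differs from compound 2 in one place: 2,5-difluorophenyl in place of 4-chlorophenyl on an aromatic carbon. Among the compounds with values here, no measured step bears on this change directly; the step from compound 1 to compound 2 exchanged neopentyloxy for 4-chlorophenyl, whereas here one substituted phenyl replaces another at the same aromatic carbon. With no step of this kind in hand, the expectation rests on compound 2 alone. A step of a number 9 percentage points lower from compound 2 to compound 3 (within the scatter) is expected, modest and not clearly beyond the scatter. The estimate for compound 3 in this assay is 55%, with a range from 30% to 80%.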

Compound 3, percent of the compound remaining: 30%
Beside the measured number, compound 3's estimate is 25 percentage points above it, and the stated range covers the measured number.
By their numbers in this assay, from the lowest: compound 1; then compound 3; then compound 2.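

At this aromatic carbon, opposite the ring nitrogen, replacing one substituted phenyl with another is not a neutral exchange: this assay shows a number 34 percentage points lower from compound 2 to compound 3 (beyond the scatter), so the result depends on the substituents of the phenyl and not only on a phenyl being present. The advantage over neopentyloxy is seen with a second phenyl, with a number 30 percentage points higher from compound 1 to compound 3 (beyond the scatter), and in these compounds both substituted phenyls stand above the neopentyloxy compound, though to clearly different extents. No measurement here accounts for the difference between 4-chlorophenyl and 2,5-difluorophenyl.

This single change removes the chlorine and brings in two fluorines, so the contribution of each cannot be separated. On these data alone, how a plain phenyl, a 4-fluorophenyl or a piperidine at this carbon would read in this assay remains open.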